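Lengthening an Ether Chain: Methoxy to Pentyloxy

This account rests on a few compounds, and the source may have more. Where it says the series, first, only, none or still open, it means among the compounds named here.

Three compounds have been measured in a functional assay on J774.A1 cells (Mus musculus) for inhibition, read by immunoassay, with a stated time of 12 h, tested at 30 uM; on this read-out lower numbers stand for less inhibition and higher numbers for more inhibition at the one concentration tested (going by the name of the read-out):
compound 1, `COCOc1ccccc1C1CC(=O)c2ccccc2O1`, gives 33.3%;
compound 2, `CCOc1ccccc1C1CC(=O)c2ccccc2O1`, gives 27.7%;
compound 3, `COc1ccccc1C1CC(=O)c2ccccc2O1`, gives 38.3%.

Compound 3 carries the highest of these three numbers. Its separation from compound 1 is within the scatter, a number 5 percentage points higher from compound 1 to compound 3 (within the scatter), so the two cannot be told apart, but its separation from compound 2 is a clear one, a number 10.6 percentage points higher from compound 2 to compound 3 (beyond the scatter). All three share the same core and differ only in what sits on the oxygen attached to the aromatic ring.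

Compound 4, `CCCCCOc1ccccc1C1CC(=O)c2ccccc2O1`, differs from compound 3 by butyl in place of hydrogen on a saturated chain carbon bound to an oxygen on an aromatic ring. The step that bears most directly on this change is the one in which that same chain grows by a single carbon, read in reverse: compound 2, with ethoxy, sits below compound 3, a number 10.6 percentage points higher from compound 2 to compound 3 (beyond the scatter). The step from compound 1, a number 5 percentage points higher from compound 1 to compound 3 (within the scatter), points the same way but stays within the scatter. Growing the chain by four carbons at once is therefore expected to lower the number in this assay, by a step at least as large as the one-carbon case, though no measured compound reaches a chain of this length, so the range is kept wide. Compound 4 is estimated at 24%, between 8% and 40%. This estimate corresponds to an expected step of a number 14.3 percentage points lower from compound 3 to compound 4 (beyond the scatter).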

Compound 4, a percentage reported as inhibition, at one concentration (the size of the read-out at that concentration, not a potency): 40.1%
For compound 4 the middle estimate is 16.1 percentage points below the measured one; the measured number lies above the stated range.
By their numbers in this assay, from the lowest: compounds 2, 1, 3 and 4 (each within the scatter of the next, the first and the last beyond it).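

In this assay the pentyloxy chain of compound 4 cannot be told apart from the methoxy group of compound 3 (a number 1.8 percentage points higher from compound 3 to compound 4 (within the scatter)), so the number stays level with a much longer chain at this place, which the shorter groups alone could not show. The picture is therefore not one of the number falling as the chain grows: compound 2, with its ethoxy group, goes against any simple trend with length, since it alone stands clearly apart from compound 4 (a number 12.4 percentage points higher from compound 2 to compound 4 (beyond the scatter)), whereas the difference from compound 1 stays unresolved (a number 6.8 percentage points higher from compound 1 to compound 4 (within the scatter)). No measurement shown explains why the ethoxy compound sits apart or why the number stays level with a long chain.

Going by these compounds, it remains open whether the low number for compound 2 is a real feature of short chains, which propyloxy and butyloxy groups would help to settle, and whether the number stays level with a longer chain such as octyloxy or with a chain ending in an amine or a carboxylic acid. With only one concentration tested, these numbers also give no potency for any of the compounds.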